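The compounds below may be only part of what the source reports. "The series", "measured", "known", "first", "only" and "open" are said of these compounds alone.

The series shares a single core and varies the aryl group on one of its phenyl rings. Compound 1 `CC1(c2ccc(-c3ccco3)cc2)CC(S(=O)(=O)c2ccc(F)cc2)=C(c2ccc(/C(N)=N\O)cc2)O1` gives 7010 nM in an ADME assay on HepG2 cells (Homo sapiens) for cytotoxicity, read by MTT assay, with a stated time of 72 h; a lower number here means that less compound is tolerated, a higher number that more compound is tolerated. Compound 2 `Cc1ccc(-c2ccc(C3(C)CC(S(=O)(=O)c4ccc(F)cc4)=C(c4ccc(/C(N)=N\O)cc4)O3)cc2)cc1` gives 13700 nM, and compound 3 `CC1(c2ccc(-c3ccc(/C(N)=N\O)cc3)cc2)CC(S(=O)(=O)c2ccc(F)cc2)=C(c2ccc(/C(N)=N\O)cc2)O1` gives 15300 nM; compound 3 has the highest number of the three, with compound 2 within the scatter of it and compound 1 the furthest away. Compound 4 `COc1cc(-c2ccc(C3(C)CC(S(=O)(=O)c4ccc(F)cc4)=C(c4ccc(/C(N)=N\O)cc4)O3)cc2)cc(OC)c1OC` is not yet measured. It differs from compound 3 by a group of 12 heavy atoms (9 carbon, 3 oxygen; one six-membered aromatic ring of carbon only) in place of a group of 10 heavy atoms (7 carbon, 2 nitrogen, 1 oxygen; one six-membered aromatic ring of carbon only), on an aromatic carbon. Among the compounds with values here, two measured steps bear on this exchange of one aryl group for another: a 2.0-fold higher number from compound 1 to compound 2 (0.29 log units; within the scatter) and a 2.2-fold higher number from compound 1 to compound 3 (0.34 log units; beyond the scatter), while a 1.1-fold higher number from compound 2 to compound 3 (0.05 log units; within the scatter) shows that two different aryl groups at this position can also leave the number unchanged. Since none of these steps exceeds a modest size, the change from compound 3 to compound 4 is expected to be a 1.4-fold lower number from compound 3 to compound 4 (0.14 log units; within the scatter), with no clear direction. Compound 4 is therefore estimated to give 11000 nM in this assay, within a range of 4500 nM to 27000 nM.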

Compound 4, half-maximal cytotoxic concentration: > 50000 nM
Compound 4 ended at the assay's limit (the forecaster's own chance of this, stated with the estimate: 10%); middle value at least 4.5-fold (0.65 log units) from the limit.
By their numbers in this assay, from the lowest: compounds 1, 2 and 3 (each within the scatter of the next, the first and the last beyond it). At a limit, above all of these: compound 4.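

In this assay, compound 4 stands at a limit of the assay, > 50000 nM, and not at a number. The 3,4,5-trimethoxyphenyl group nevertheless gives readable steps against all three earlier aryl groups: an at least 3.2-fold higher number from compound 3 to compound 4 (0.51 log units; beyond the scatter), an at least 3.6-fold higher number from compound 2 to compound 4 (0.56 log units; beyond the scatter) and an at least 7.1-fold higher number from compound 1 to compound 4 (0.85 log units; beyond the scatter). Among the earlier compounds, the largest change at this position was a 2.2-fold higher number from compound 1 to compound 3 (0.34 log units; beyond the scatter), so the result shows that exchanging this aryl group can raise the tolerated concentration further than those compounds revealed.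

How far compound 4 lies past this point remains unknown, since only a limit is available: the limit of > 50000 nM in this assay, at which 1 of the 4 values shown sits. The compounds shown also leave open whether all three methoxy groups are needed, and whether a single methoxy group, a hydroxyl or an amine on this ring would give a similar number.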